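Methyl for methylsulfonyl on the eight-carbon hydroxamate chain

The compounds below may be only part of what the source reports. "The series", "measured", "known", "first", "only" and "open" are said of these compounds alone.

Values in a functional assay on ASPC1 cells (Homo sapiens) for cytotoxicity; a higher number here means a weaker inhibitor, a lower number a stronger inhibitor:
- compound 1 `O=C(CCCCCCC(=O)Nc1nc2ccccc2s1)NO`: 5.69 ug/mL
- compound 2 `CS(=O)(=O)c1ccc2nc(NC(=O)CCCCCCC(=O)NO)sc2c1`: 13.5 ug/mL
- compound 3 `CS(=O)(=O)c1ccc2nc(NC(=O)CCCCC(=O)NO)sc2c1`: > 30 ug/mL (a limit)

Not yet measured: compound 4 `Cc1ccc2nc(NC(=O)CCCCCCC(=O)NO)sc2c1`.

Compound 2, at 13.5 ug/mL, carries the higher of the two exact numbers in this assay, with compound 1 at 5.69 ug/mL the nearest. Compound 3 gives only a limit, > 30 ug/mL.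

The change under consideration is methyl in place of methylsulfonyl on an aromatic carbon. The closest measured step concerns the same group on the same kind of carbon. Placing methylsulfonyl where hydrogen stood gave a 2.4-fold higher number from compound 1 to compound 2 (0.38 log units; beyond the scatter), a modest step beyond the scatter. The other measured step, an at least 2.2-fold higher number from compound 2 to compound 3 (0.34 log units; beyond the scatter), alters the chain and leaves the aromatic carbon untouched, so it bears little on this change.

Compound 4 also lacks methylsulfonyl, so a modest move to a lower number is expected, towards compound 1 at 5.69 ug/mL. Among the compounds with values here, no compound yet shows methyl itself, which keeps the range wide. The expected change is a 2.1-fold lower number from compound 2 to compound 4 (0.32 log units; beyond the scatter). For compound 4 the estimated value is 6.5 ug/mL, with an expected range of 2.8 ug/mL to 14 ug/mL.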

Compound 4, half-maximal inhibitory concentration: 0.54 ug/mL
For compound 4 the middle estimate is 12-fold (1.08 log units) above the measured one, outside the stated range (below it).
By their numbers in this assay, from the lowest: compound 4; then compound 1; then compound 2. At a limit, above all of these: compound 3.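

In this assay methyl in place of methylsulfonyl gives a 25-fold lower number from compound 2 to compound 4 (1.40 log units; beyond the scatter) and is a large step, much larger than any step measured earlier, so this aromatic carbon is far more sensitive to its substituent than the first two exact values suggested. Methyl in place of hydrogen on the same carbon gives an 11-fold lower number from compound 1 to compound 4 (1.02 log units; beyond the scatter) and is also large, which means the gain at compound 4 is not just the loss of methylsulfonyl: of the two substituents seen here, methylsulfonyl goes with a higher number than hydrogen and methyl with a lower one. Nothing measured in this series accounts for either step, and the size and direction of the methyl effect remain unexplained.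

Going by these compounds, with only hydrogen, methyl and methylsulfonyl seen on this carbon, it remains open whether ethyl, methoxy, chlorine or an amine there would follow methyl towards lower numbers or methylsulfonyl towards higher ones. On these data alone, it is also open whether methyl keeps its advantage on the chain of compound 3 or on a longer chain than that of compound 4, and whether the same order holds in other cell lines.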